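The source may report more compounds than this note shows. Statements on the series, on what has been measured and on what is new or still open speak of the compounds shown alone.

Measured compounds:
compound 1 `Nc1sc(-c2ccccc2)c(-c2cccc(C(F)(F)F)c2)c1C(=O)c1ccccc1` — 2.3 uM
compound 2 `COc1ccc(-c2sc(N)c(C(=O)c3ccccc3)c2-c2cccc(C(F)(F)F)c2)cc1` — > 10 uM
compound 3 `CCOC(=O)c1c(N)sc(-c2ccccc2)c1-c1cccc(C(F)(F)F)c1` — > 10 uM

In a functional assay on CHO-K1 cells for agonist activity at adenosine receptor A1 (Homo sapiens), read by GTPgammaS binding (on this read-out lower numbers stand for an effect already at smaller amounts and higher numbers for an effect only at larger amounts of compound), compound 1 gives 2.3 uM. For compound 2 the value of > 10 uM is a limit of this assay, not a number. For compound 3 the value of > 10 uM is likewise only a limit; compound 3 thus stands at the weak end of the three values shown, together with compound 2, both at the limit of > 10 uM in this assay, at which 2 of the 3 values shown sit.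

Compound 4 `CCOC(=O)c1c(N)sc(-c2ccc(C(C)=O)cc2)c1-c1cccc(C(F)(F)F)c1` is not yet measured. It differs from compound 3 by acetyl in place of hydrogen on an aromatic carbon.

Going by the values given here, two measured steps bear on this. The step of an at least 4.3-fold higher number from compound 1 to compound 3 (0.63 log units; beyond the scatter) puts compound 3 at the limit already. The step of an at least 4.3-fold higher number from compound 1 to compound 2 (0.63 log units; beyond the scatter) shows that a substituent on the aromatic carbon of the pendant phenyl, para to a large group, lowered activity beyond the scatter; an acetyl at the same place on compound 3 is expected to behave no better. Hence no gain is expected; the likely outcome is that compound 4 again reaches only the limit.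

Estimated step: a step that the limit leaves unreadable from compound 3 to compound 4, with compound 4 expected at 20 uM (range 8 uM to 60 uM).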

Compound 4, concentration for half-maximal effect: > 10 uM
Compound 4: only a limit was reported (the forecaster's own chance of this, stated with the estimate: 85%); the middle value lies beyond the limit too.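

No step can be read from compound 3 to compound 4, as each carries only a limit: the limit of > 10 uM in this assay, at which 3 of the 4 values shown sit.

The compounds shown leave open whether going from phenyl to 4-acetylphenyl changes activity at all, either here or on the core of compound 1, which gives a measurable value.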